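A few compounds are considered here, and "the series" means these few. Any claim that something is new, unique, unknown or untested is made for them only; others in the source may bear on it.

Of the compounds shown here, two have so far been tested in a functional assay on MGC-803 cells (Homo sapiens) for cytotoxicity, read by MTT assay, with a stated time of 48 h; on this read-out higher numbers stand for weaker inhibition and lower numbers for stronger inhibition. Compound 1 `CC1=NN(S(=O)(=O)c2ccc(C)cc2)C(c2cc(Br)ccc2O)C1` gives 30700 nM, and compound 2 `CC1=NN(S(=O)(=O)c2ccc([N+](=O)[O-])cc2)C(c2cc(Br)cc(Br)c2O)C1` gives 40100 nM. These two numbers lie within the usual scatter of each other, so repeat measurements could not reliably tell them apart, and neither compound can be ranked above the other.

The next compound to be tested is compound 3 `CC1=NN(S(=O)(=O)c2ccc(C)cc2)C(c2cc(Br)cc(Br)c2O)C1`, which differs from compound 2 in one place. A methyl stands in place of a nitro on an aromatic carbon, turning a 4-nitrophenyl into a 4-methylphenyl: methyl in place of nitro on an aromatic carbon.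

Among the measured compounds shown here, no measured pair shows what this swap does on its own, so the data give no direction for the change. For the measured compounds named here, the only guide is how close the two known numbers are, with compound 1 at 30700 nM and compound 2 at 40100 nM. A shift beyond the scatter is therefore not expected in this assay.

The estimate amounts to an expected 1.3-fold lower number from compound 2 to compound 3 (0.13 log units; within the scatter), a step within the scatter. Compound 3 is estimated at 30000 nM, with the result expected to fall between 12000 nM and 75000 nM.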

Compound 3, half-maximal inhibitory concentration: "not active" (no number reported)
Compound 3: no number reported, and the estimate cannot be compared.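

Among the compounds shown here, compound 3 is reported in this assay only as "not active", without a number, so no step from compound 2 to compound 3 can be read. The compounds shown leave open what the change from 4-nitrophenyl to 4-methylphenyl does to this read-out on its own. No outside evidence bears on this result.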